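The source may hold more compounds than are shown below. What is called first, only, known or untested is meant among the compounds shown, and "the series" means these compounds.

Measured compounds, read in a functional assay on HCT-116 cells (Homo sapiens) for antiproliferative activity, read by MTT assay, with a stated time of 48 h; on this read-out lower numbers stand for stronger inhibition and higher numbers for weaker inhibition:
Compound 1 `COc1cc(/C=C/C(C)=O)ccc1OCc1cn(-c2ccc(/N=N/c3ccccc3)cc2)nn1` gives only a limit of the assay, > 100000 nM.
Compound 2 `COc1cc(/C=C/C(C)=O)ccc1OCc1cn(-c2ccc(NC(=O)c3ccccc3)cc2)nn1` likewise gives only a limit of the assay, > 100000 nM.
Compound 3 `COc1cc(/C=C/C(C)=O)ccc1OCc1cn(-c2ccc(C)cc2)nn1` gives 76600 nM.

Going by the values given here, compound 3 thus holds the only actual number among the three; the other two values are limits, and the limit of > 100000 nM in this assay, at which 2 of the 3 values shown sit, tells where those two sit. Compound 4 `CCOC(=O)c1ccc(-n2cc(COc3ccc(/C=C/C(C)=O)cc3OC)nn2)cc1` has not yet been measured. It differs from compound 3 by ethoxycarbonyl in place of methyl on an aromatic carbon. Among the compounds with values here, two measured steps touch this same position: an at least 1.3-fold lower number from compound 1 to compound 3 (0.11 log units; that floor lies within the scatter) and an at least 1.3-fold lower number from compound 2 to compound 3 (0.11 log units; that floor lies within the scatter). In both, a larger group on that aromatic carbon was exchanged for methyl and the number fell, but only by a floor that lies within the scatter, so the true size of either step is not readable. Ethoxycarbonyl is again larger than methyl, so for compound 4 a step toward a higher number is expected, a 1.3-fold higher number from compound 3 to compound 4 (0.12 log units; within the scatter), with a real chance that this assay reports only a limit once more. The expected value for compound 4 is 100000 nM, within a range from 40000 nM to 300000 nM.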

Compound 4, half-maximal inhibitory concentration: 78900 nM
Compound 4: the middle estimate sits 1.3-fold (0.10 log units) above what was measured, and the stated range covers the measured number.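

Exchanging methyl for ethoxycarbonyl, on an aromatic carbon para to a large group, gives in this assay a 1.0-fold higher number from compound 3 to compound 4 (0.01 log units; within the scatter), so the two compounds cannot be told apart, even though ethoxycarbonyl adds heavy atoms and hydrogen-bond acceptors. A larger group on this carbon therefore need not end in a limit of the assay, as the ring-bearing groups of compound 1 and compound 2 did. The other two new steps, an at least 1.2-fold lower number from compound 2 to compound 4 (0.10 log units; that floor lies within the scatter) and an at least 1.2-fold lower number from compound 1 to compound 4 (0.10 log units; that floor lies within the scatter), give only floors and not true sizes, because each starts from a limit: the limit of > 100000 nM in this assay, at which 2 of the 4 values shown sit.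

Going by these compounds, what a carboxylic acid, an amine or a longer chain on this carbon would give stays open. So does whether any group here can bring the number clearly below that of compound 3.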